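Trimming the Methoxy Group from Compound 2

The source may hold more compounds than are shown below. What is called first, only, known or untested is meant among the compounds shown, and "the series" means these compounds.

Among the compounds with values here, compound 2 `COc1ccc(/C=C/C(=O)c2ccc(Nc3cc(C)nc4nc(SCc5nc6ccccc6[nH]5)nn34)cc2)cc1F` stands at the lowest of the two numbers so far in a functional assay on SW-620 cells (Homo sapiens) for cytotoxicity, read by MTT assay, with stated times of 4 h and 72 h, tested at 2 uM (on this read-out lower numbers stand for stronger inhibition and higher numbers for weaker inhibition), where compound 2 gives 140 nM. Its nearest neighbour, compound 1 `Cc1cc(Nc2ccc(C(=O)/C=C/c3ccccc3F)cc2)n2nc(SCc3nc4ccccc4[nH]3)nc2n1`, gives 250 nM in this assay. Within the data shown here, the single measured step, a 1.8-fold lower number from compound 1 to compound 2 (0.25 log units; within the scatter), swaps one substituted phenyl for another and stays within the scatter. Compound 3 `Cc1cc(Nc2ccc(C(=O)/C=C/c3cccc(F)c3)cc2)n2nc(SCc3nc4ccccc4[nH]3)nc2n1` differs from compound 2 by hydrogen in place of methoxy on an aromatic carbon. Among the measured compounds shown here, no measured step concerns removal of a methoxy group on its own, so the only guidance is that altering substitution on this same ring has so far moved the number within the scatter. The step is therefore expected to be a 1.4-fold higher number from compound 2 to compound 3 (0.15 log units; within the scatter), that is, nothing beyond the scatter in either direction. The estimate for compound 3 in this assay is 200 nM, with a range from 90 nM to 450 nM.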

Compound 3, half-maximal inhibitory concentration: 590 nM
Compound 3: middle estimate off by 3.0-fold (0.47 log units), on the low side; measured number outside the range, above it.
By their numbers in this assay, from the lowest: compounds 2 and 1 (each within the scatter of the next); then compound 3.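

Within the data shown here, replacing methoxy with hydrogen on the 3-fluoro-4-methoxyphenyl ring gives a 4.2-fold higher number from compound 2 to compound 3 (0.62 log units; beyond the scatter) in this assay and is the first change at this ring to go beyond the scatter, so the methoxy group para to the large group matters for this number even though the earlier swap of whole rings did not reveal it. The placing of the fluoro group also matters once methoxy is absent, since 3-fluorophenyl in place of 2-fluorophenyl gives a 2.4-fold higher number from compound 1 to compound 3 (0.37 log units; beyond the scatter) as a second step beyond the scatter, though a modest one.

The compounds shown leave open whether ethoxy, hydroxyl or an amine at the methoxy position would keep the lower number of compound 2. They also leave open whether methoxy on a ring without the fluoro group would do the same. Nothing at hand explains the size of either step.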